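The compounds below may be only part of what the source reports. "The series", "measured", "known", "first", "only" and "open" are said of these compounds alone.

Compound 3 `ClCc1ccccc1Cn1cnc2ncnc(Cl)c21` stands second highest of the three numbers in a functional assay on BT-549 cells (Homo sapiens) for cytotoxicity, read by sulforhodamine B assay, with a stated time of 48 h (a lower number here means a stronger inhibitor of growth, a higher number a weaker inhibitor of growth), where compound 3 gives 2450 nM. Compound 1 `ClCc1ccccc1Cn1cnc2c(Cl)nc(Cl)nc21` gives the lowest number, 450 nM, and compound 2 `ClCc1cccc(Cn2cnc3c(Cl)ncnc32)c1` gives the highest, 15100 nM. Compound 4 `ClCc1ccccc1Cn1cnc2nc(Cl)nc(Cl)c21` differs from compound 3 by chloro in place of hydrogen on an aromatic carbon. Within the data shown here, no two measured compounds differ in only one place, so no single step can be read from them directly. Still, the added chloro is expected to lower the number somewhat, because compound 1, which also carries a second chloro on its core, gives 450 nM. The expected step is a 2.7-fold lower number from compound 3 to compound 4 (0.43 log units; beyond the scatter). Compound 4 is therefore estimated to give 900 nM, with a likely range from 300 nM to 3000 nM.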

Compound 4, concentration for 50% growth inhibition: 1340 nM
Estimate against measurement, compound 4: 1.5-fold (0.17 log units) below; the range from low to high includes it.
By their numbers in this assay, from the lowest: compound 1; then compounds 4 and 3 (each within the scatter of the next); then compound 2.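

In this assay, among these compounds, this is the first comparison of two compounds that differ in only one place (a 1.8-fold lower number from compound 3 to compound 4 (0.26 log units; within the scatter)), and the step lies within the usual scatter. Chloro in place of hydrogen on this aromatic carbon, between two ring nitrogen atoms, therefore makes no clear difference to growth inhibition. No supporting measurement is available to explain this result.

As far as these compounds go, whether an amine or a methoxy group on this same carbon would shift the number beyond the scatter remains open.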